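Acetyl replaced by a silicon-bearing group on the core

The compounds below may be only part of what the source reports. "The series", "measured", "known", "first", "only" and "open" are said of these compounds alone.

Measured compounds:
compound 1 `COc1ccc(C2=C(c3cc(OC)c(OC)c(OC)c3)C(=O)C(OC(C)=O)C2)cc1F`: 41 ug/mL
compound 2 `COc1ccc(C2=C(c3cc(OC)c(OC)c(OC)c3)C(=O)C(OC(C)=O)C2)cc1O`: > 100 ug/mL
compound 3 `COc1ccc(C2=C(c3cc(OC)c(OC)c(OC)c3)C(=O)C(OC(C)=O)C2)cc1`: 18 ug/mL

In an ADME assay on ECV-304 cells (Homo sapiens) for cytotoxicity, read by MTT assay, with a stated time of 72 h (a higher number here means a weaker inhibitor, a lower number a stronger inhibitor), compound 3 gives the lowest of the two numbers shown; the nearest is compound 1, with a 2.3-fold lower number from compound 1 to compound 3 (0.36 log units; beyond the scatter). Compound 2 reached only the limit of this assay (the limit of > 100 ug/mL in this assay, at which 1 of the 3 values shown sits). Compound 4 `COc1ccc(C2=C(c3cc(OC)c(OC)c(OC)c3)C(=O)C(O[SiH2]C(C)(C)C)C2)cc1` differs from compound 3 by a group of 5 heavy atoms (4 carbon, 1 silicon; no ring) in place of a group of 3 heavy atoms (2 carbon, 1 oxygen; no ring), on an oxygen on a saturated carbon. The measured steps, an at least 2.4-fold higher number from compound 1 to compound 2 (0.38 log units; beyond the scatter) and an at least 5.5-fold lower number from compound 2 to compound 3 (0.74 log units; beyond the scatter) among them, all change a substituent on an aromatic carbon and do not touch the oxygen on the saturated carbon, so none of them bears directly on this change. For compound 4 the expectation is therefore a step of a 1.4-fold higher number from compound 3 to compound 4 (0.14 log units; within the scatter), not beyond the scatter in either direction. Compound 4 is estimated at 25 ug/mL, between 8 ug/mL and 80 ug/mL.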

Compound 4, half-maximal inhibitory concentration: 16 ug/mL
Compound 4: the middle estimate sits 1.6-fold (0.19 log units) above what was measured; the measured number falls inside the stated range.
By their numbers in this assay, from the lowest: compounds 4 and 3 (each within the scatter of the next); then compound 1. At a limit, above all of these: compound 2.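

In this assay, the oxygen on a saturated carbon accepts a group of 5 heavy atoms (4 carbon, 1 silicon) in place of acetyl with no step beyond the scatter: a 1.1-fold lower number from compound 3 to compound 4 (0.05 log units; within the scatter). This is the only change shown at this oxygen, as the earlier steps all sit on an aromatic carbon. Nothing in the data shown gives a reason for this result.

Open, on these data alone, is whether a free hydroxy, an amine or a longer chain at this oxygen's place would read the same. Also open, as far as these compounds go, is whether the silicon-bearing group reads the same with fluoro or hydroxy on the aromatic carbon.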